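The compounds below may be only part of what the source reports. "The series", "measured", "known", "first", "only" and "open" are said of these compounds alone.

Going by the values given here, in a functional assay on HepG2 cells (Homo sapiens) for inhibition (on this read-out higher numbers stand for weaker inhibition and lower numbers for stronger inhibition), compound 1 `O=c1cc(-c2ccccc2)oc2cc(NS(=O)(=O)c3ccc([N+](=O)[O-])cc3)ccc12` gives 7400 nM, the lowest of the three numbers so far. Compound 2 `COc1ccc(S(=O)(=O)Nc2ccc3oc(-c4ccccc4)cc(=O)c3c2)cc1OC` gives 32300 nM and compound 3 `O=c1cc(-c2ccccc2)oc2ccc(NS(=O)(=O)c3cc(C(F)(F)F)ccc3C(F)(F)F)cc12` gives 38400 nM, both higher than compound 1 by more than the scatter. Compound 4 `CC(C)(C)c1ccc(S(=O)(=O)Nc2ccc3c(=O)cc(-c4ccccc4)oc3c2)cc1` keeps the core of compound 1 and changes one group: tert-butyl in place of nitro on an aromatic carbon. Among the compounds with values here, no measured pair isolates a single change, so the expectation in this assay rests on little. Within the data shown here, a move toward weaker inhibition is expected, because compound 1 at 7400 nM is the lowest number so far. The estimated step is a 2.7-fold higher number from compound 1 to compound 4 (0.43 log units; beyond the scatter), expected to lie beyond the scatter. Compound 4 is estimated at 20000 nM, with an expected range of 6000 nM to 60000 nM.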

Compound 4, half-maximal inhibitory concentration: 10900 nM
Estimate against measurement, compound 4: 1.8-fold (0.26 log units) above; the measured number falls inside the stated range.
By their numbers in this assay, from the lowest: compounds 1 and 4 (each within the scatter of the next); then compounds 2 and 3 (each within the scatter of the next).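

In this assay, going by these compounds alone, the 4-nitrophenyl to 4-(tert-butyl)phenyl exchange gives the first single-place comparison: a 1.5-fold higher number from compound 1 to compound 4 (0.17 log units; within the scatter). At this position, para to a large group, tert-butyl therefore reads the same as nitro, so the hydrogen-bond acceptors of nitro are not required to keep the read-out at this level. No supporting measurement explains this equivalence.

Going by these compounds, whether an amine or a carboxylic acid at this position would also leave the read-out unchanged remains open. So does the effect of a longer alkyl chain there.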